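Trifluoromethoxy to hydroxy: an open step in growth inhibition

The source may report more compounds than this note shows. Statements on the series, on what has been measured and on what is new or still open speak of the compounds shown alone.

In a functional assay on MCF7 cells (Homo sapiens) for inhibition, read by sulforhodamine B assay (on this read-out higher numbers stand for weaker inhibition of growth and lower numbers for stronger inhibition of growth), compound 3 (`Cc1ccc2[nH]c(-c3ccc(-c4ccc(-c5ccc(OC(F)(F)F)cc5)cc4)cc3)nc2c1`) gives 31000 nM, which places it level with compound 2 (`Cc1ccc2[nH]c(-c3ccc(-c4ccc(-c5ccc(F)cc5)cc4)cc3)nc2c1`) at 30200 nM. Compound 1 (`Cc1ccc2[nH]c(-c3ccc(-c4ccc(-c5ccc(N(C)C)cc5)cc4)cc3)nc2c1`) stands apart at 3130 nM. Compound 4 (`Cc1ccc2[nH]c(-c3ccc(-c4ccc(-c5ccc(O)cc5)cc4)cc3)nc2c1`) differs from compound 3 by hydrogen in place of trifluoromethyl on an oxygen on an aromatic ring, or trifluoromethoxy to hydroxy.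

For the measured compounds named here, no measured compound carries hydroxy, so the evidence is indirect. The same place can clearly move the number, as a 9.9-fold higher number from compound 1 to compound 3 (1.00 log units; beyond the scatter) and a 9.6-fold higher number from compound 1 to compound 2 (0.98 log units; beyond the scatter) show. Not every exchange does so, however, since a 1.0-fold higher number from compound 2 to compound 3 (0.01 log units; within the scatter) stays within the scatter. A partial move toward compound 1 therefore seems the most reasonable expectation, with wide uncertainty. The expected change is a 3.4-fold lower number from compound 3 to compound 4 (0.54 log units; beyond the scatter), toward a lower number. For compound 4 the estimated value is 9000 nM, with an expected range of 2500 nM to 30000 nM.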

Compound 4, concentration for 50% growth inhibition: 12100 nM
Compound 4: the middle estimate sits 1.3-fold (0.13 log units) below what was measured; measured number inside the range.
By their numbers in this assay, from the lowest: compound 1; then compound 4; then compounds 2 and 3 (each within the scatter of the next).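

In this assay, for the compounds shown here, hydroxy is the first group at this position to stand apart from both fluoro and trifluoromethoxy while not matching dimethylamino: the result is a 2.6-fold lower number from compound 3 to compound 4 (0.41 log units; beyond the scatter) and a 2.5-fold lower number from compound 2 to compound 4 (0.40 log units; beyond the scatter), yet also a 3.9-fold higher number from compound 1 to compound 4 (0.59 log units; beyond the scatter). The four groups shown therefore fall on three levels rather than two, with compounds 2 and 3 sharing the upper level, and removing trifluoromethyl from the oxygen is enough to shift the number even though the oxygen itself stays in place. Nothing available explains this order of the groups.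

The compounds shown leave open whether methoxy would stay with compound 3 or move toward compound 4, and whether a primary amine would approach compound 1. They also leave open how a carboxylic acid or a longer chain at this position would read.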